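This account rests on a few compounds, and the source may have more. Where it says the series, first, only, none or still open, it means among the compounds named here.

Measured in a functional assay on NALM-6 cells (Homo sapiens) for cytotoxicity, with a stated time of 72 h; a higher number here means that more compound is needed for the effect, a lower number that less compound is needed:
- Compound 1 `C=C[C@@](C)(/C=C/c1ccc(OS(=O)(=O)C(F)(F)F)cc1)CCC=C(C)C`: > 43400 nM, a limit
- Compound 2 `C=C[C@@](C)(/C=C/c1ccc(Nc2ccc(Cl)cc2)cc1)CCC=C(C)C`: > 43400 nM, a limit
- Compound 3 `C=C[C@@](C)(/C=C/c1ccc(-c2ccccc2)cc1)CCC=C(C)C`: > 43400 nM, a limit

Compound 3 has no exact number on this scale. Its entry shares the pattern of the whole set, which is the limit of > 43400 nM in this assay, at which 3 of the 3 values shown sit.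

Compound 4 `C=C[C@@](C)(/C=C/c1ccc(-c2ccc(F)cc2)cc1)CCC=C(C)C` differs from compound 3 in one place: fluoro in place of hydrogen on an aromatic carbon. This is fluoro in place of hydrogen on an aromatic carbon, para to a large group, so phenyl becomes 4-fluorophenyl.

The measured steps are a step that the two limits leave unreadable from compound 1 to compound 2, a step that the two limits leave unreadable from compound 1 to compound 3 and a step that the two limits leave unreadable from compound 2 to compound 3. None of them is this fluoro change, and none has a size that can be read.

The expectation therefore rests on compound 3, whose entry of > 43400 nM is a limit. No step beyond the usual scatter is expected in this assay, and no direction can be given. The expected outcome is a number no higher from compound 3 to compound 4 (the limit leaves the size open).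

Compound 4 is most likely to be reported as a limit as well. For compound 4 the estimated value is 43400 nM, with an expected range from 20000 nM to 80000 nM.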

Compound 4, half-maximal effective concentration: > 43400 nM
Compound 4: only a limit was reported; the forecaster's own chance of this, stated with the estimate: 85%; the middle value lies on the limit itself.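

In this assay compound 4 gives > 43400 nM, which is a limit. Its steps from compound 1, compound 2 and compound 3 cannot be read, and all four compounds share one entry: the limit of > 43400 nM in this assay, at which 4 of the 4 values shown sit.

The compounds shown leave open how much of any of them is needed for the effect, and so whether the fluoro group makes any difference.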